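Benzyl Swap on a Diamino Core: From Dichloro to Methoxy

This account rests on a few compounds, and the source may have more. Where it says the series, first, only, none or still open, it means among the compounds named here.

Measured compounds:
Compound 1 `Nc1cc(N)c2nc(-c3ccccc3)c(NCc3ccc(Cl)c(Cl)c3)nc2c1` in a functional assay on Malme-3M cells (Homo sapiens) for inhibition, read by sulforhodamine B assay, with a stated time of 48 h (on this read-out lower numbers stand for stronger inhibition of growth and higher numbers for weaker inhibition of growth), gives 3390 nM
Compound 2 `CCOC(=O)[C@H](CCC(=O)O)NC(=O)c1ccc(Sc2nc3cc(N)cc(N)c3nc2-c2ccccc2)cc1` in this assay gives 19500 nM

Compound 1 holds the lowest number of the two in this assay; compound 2 sits well beyond the scatter above it. Compound 3 `COc1ccc(CNc2nc3cc(N)cc(N)c3nc2-c2ccccc2)cc1` differs from compound 1 by 4-methoxyphenyl in place of 3,4-dichlorophenyl on a saturated chain carbon bound to a nitrogen on an aromatic ring. Among the compounds with values here, no measured pair shows this change, so the expectation rests on compound 1 alone. The step of a 2.1-fold higher number from compound 1 to compound 3 (0.31 log units; beyond the scatter) is estimated to be a modest loss, beyond the scatter but not large. Compound 3 is therefore expected to give about 7000 nM, within a range from 2500 nM to 25000 nM.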

Compound 3, concentration for 50% growth inhibition: 10700 nM
Compound 3: the middle estimate sits 1.5-fold (0.18 log units) below what was measured; the measured number falls inside the stated range.
By their numbers in this assay, from the lowest: compound 1; then compounds 3 and 2 (each within the scatter of the next).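

In this assay, within the data shown here, the exchange of 3,4-dichlorophenyl for 4-methoxyphenyl gives a 3.2-fold higher number from compound 1 to compound 3 (0.50 log units; beyond the scatter), the first measured step at this place, on a saturated chain carbon bound to a nitrogen on an aromatic ring. The change costs only modestly, so growth inhibition at this place does not depend strictly on the 3,4-dichlorophenyl group. No available evidence bears on why the step runs this way.

Open remains whether the step follows the loss of the chlorines or the gain of the methoxy. Also open, on these data alone, is how 4-chlorophenyl, or a phenyl ring carrying a carboxylic acid, would read at this place.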